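Sulfonyl chain variants: pentyl to cyclopentyl at sulfur

A few compounds are considered here, and "the series" means these few. Any claim that something is new, unique, unknown or untested is made for them only; others in the source may bear on it.

Measured so far:
Compound 1, `CCCCCCS(=O)(=O)/C=C/c1ccc(O)c(O)c1`, in a functional assay, read by fluorescence and spectrophotometry, with a stated time of 1 h; on this read-out higher numbers stand for an effect only at larger amounts of compound and lower numbers for an effect already at smaller amounts: 7300 nM
Compound 2, `O=S(=O)(/C=C/c1ccc(O)c(O)c1)CCCCCCCCO`, in this assay: 6700 nM

Of the two numbers shown, compound 1 carries the larger, but the gap to compound 2, a 1.1-fold lower number from compound 1 to compound 2 (0.04 log units; within the scatter), is within the scatter; that step replaced hydrogen with 2-hydroxyethyl on a saturated chain carbon, six bonds along the chain from a sulfonyl sulfur.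

Compound 3, `O=S(=O)(/C=C/c1ccc(O)c(O)c1)CC1CCCC1`, is not yet measured. It differs from compound 1 by cyclopentyl in place of pentyl on a saturated chain carbon bound to a sulfonyl sulfur. Among the compounds with values here, no measured step touches the chain carbon bound to the sulfonyl sulfur, so nothing bears directly on this change; the one known step, made six bonds along the chain, stayed within the scatter. The expectation for compound 3 is therefore no step beyond the scatter, a 1.0-fold lower number from compound 1 to compound 3 (0.02 log units; within the scatter). The estimate for compound 3 is 7000 nM, with a range from 3000 nM to 16000 nM.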

Compound 3, half-maximal effective concentration: 9400 nM
For compound 3 the middle estimate is 1.3-fold (0.13 log units) below the measured one; the range from low to high includes it.
By their numbers in this assay, from the lowest: compounds 2, 1 and 3 (each within the scatter of the next).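

At the saturated chain carbon bound to a sulfonyl sulfur, cyclopentyl in place of pentyl keeps the number in this assay within the scatter (a 1.3-fold higher number from compound 1 to compound 3 (0.11 log units; within the scatter)). Within the data shown here, this is the first measured change at this position, and it shows that the ring, with the same count of heavy atoms as pentyl, gives no step beyond the scatter. No measurement at hand offers an explanation for this result.

From the compounds shown here alone, whether cyclohexyl, an amine or a carboxylic acid at this position would give a step beyond the scatter remains open.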